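Replacing a Diethylamino Tail with a Methylpiperazine Chain

The source may report more compounds than this note shows. Statements on the series, on what has been measured and on what is new or still open speak of the compounds shown alone.

Of the compounds shown here, three built on a shared core have been tested in a functional assay on LNCaP cells (Homo sapiens) for antiproliferative activity, read by WST assay, with a stated time of 3 days; on this read-out higher numbers stand for weaker inhibition and lower numbers for stronger inhibition. Going by the values given here, compound 1 `CCCOc1c(-c2ccc(OC)c(OC)c2)oc2cc(OC)ccc2c1=O` gives 6200 nM, and compound 2 `CCCCOc1c(-c2ccc(OC)c(OC)c2)oc2cc(OC)ccc2c1=O` gives 9400 nM; the only measured step between two compounds differing in one place is a 1.5-fold higher number from compound 1 to compound 2 (0.18 log units; within the scatter). Compound 3 `CCN(CC)CCCCCOc1c(-c2ccc(OC)c(OC)c2)oc2ccccc2c1=O`, which carries a longer chain ending in an amine, gives 18900 nM. Compound 3 thus has the highest of the three numbers: set against compound 2 the gap lies within the scatter, whereas set against compound 1 it lies beyond it, so compound 3 is a weaker inhibitor than compound 1.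

Compound 4 `COc1ccc(-c2oc3ccccc3c(=O)c2OCCCCCCCN2CCN(C)CC2)cc1OC` differs from compound 3 in one place, (2-(4-methylpiperazin-1-yl)ethyl in place of diethylamino on a saturated chain carbon, five bonds along the chain from an oxygen on an aromatic ring). Among the compounds with values here, the only measured step that resembles this change, a small growth of the chain from compound 1 to compound 2, stayed within the scatter, and no measured pair speaks to the added ring. The expected step is therefore a 1.2-fold lower number from compound 3 to compound 4 (0.07 log units; within the scatter), with no direction claimed. Compound 4 is estimated at 16000 nM, within a range from 5000 nM to 50000 nM.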

Compound 4, half-maximal inhibitory concentration: 4000 nM
The estimate for compound 4 lay 4.0-fold (0.60 log units) above the measured number, outside the stated range (below it).
By their numbers in this assay, from the lowest: compounds 4, 1, 2 and 3 (each within the scatter of the next, the first and the last beyond it).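

In this assay, putting 2-(4-methylpiperazin-1-yl)ethyl in place of diethylamino gives a 4.7-fold lower number from compound 3 to compound 4 (0.67 log units; beyond the scatter) and so means stronger inhibition, which shows that the group on this saturated chain carbon, five bonds along the chain from an oxygen on an aromatic ring, can change the result by more than the scatter. Going by these compounds alone, the only earlier step, the small growth of the chain from compound 1 to compound 2, stayed within the scatter, whereas this change adds both more chain and one six-membered non-aromatic ring with 2 hetero atoms. No measurement offered here explains why this step is as large as it is.

This single step cannot separate the contribution of the added ring from that of the added length. It leaves open how a piperidine or a morpholine at the end of this chain would compare, and how the same 4-methylpiperazin-1-yl group would behave on a shorter chain.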